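Aryl swap on the amine-bound chain carbon

The source may hold more compounds than are shown below. What is called first, only, known or untested is meant among the compounds shown, and "the series" means these compounds.

The three measured compounds share one core and differ only in the aryl group on a saturated chain carbon bound to an amine nitrogen. Compound 1 `COc1ccc(CNCCCNS(=O)(=O)c2cc(C(F)(F)F)cc(C(F)(F)F)c2)cc1OC` gives 3600 nM in a functional assay on BE(2)-C cells (Homo sapiens) for inhibition, read by MTT assay, with a stated time of 72 h; on this read-out higher numbers stand for weaker inhibition of growth and lower numbers for stronger inhibition of growth. Compound 2 `CC(C)(C)c1ccc(CNCCCNS(=O)(=O)c2cc(C(F)(F)F)cc(C(F)(F)F)c2)cc1` gives 2500 nM in this assay. Compound 3 `COc1cccc(CNCCCNS(=O)(=O)c2cc(C(F)(F)F)cc(C(F)(F)F)c2)c1` gives 4500 nM in this assay, the highest of the three numbers, although its gaps to compound 1 and to compound 2 are both within the scatter, so no order among the three can be read from these values.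

Compound 4 `O=S(=O)(NCCCNCc1ccc(C(F)(F)F)cc1)c1cc(C(F)(F)F)cc(C(F)(F)F)c1` is not yet measured. It differs from compound 3 as follows: 4-(trifluoromethyl)phenyl in place of 3-methoxyphenyl on a saturated chain carbon bound to an amine nitrogen. The same place has been varied before, and every such step stayed within the scatter: a 1.8-fold higher number from compound 2 to compound 3 (0.26 log units; within the scatter), a 1.4-fold lower number from compound 1 to compound 2 (0.16 log units; within the scatter) and a 1.3-fold higher number from compound 1 to compound 3 (0.10 log units; within the scatter). Three different aryl groups at this place thus give numbers that cannot be told apart. The change to compound 4 brings a fourth aryl group to the same place, so the expected step is none beyond the scatter, with a slight lean toward a lower number given the spread of the three values.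

Compound 4 is therefore expected to give about 3500 nM in this assay, with an estimated range from 1500 nM to 8000 nM. The step this estimate means for compound 4 is a 1.3-fold lower number from compound 3 to compound 4 (0.11 log units; within the scatter), which is expected to stay within the scatter.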

Compound 4, concentration for 50% growth inhibition: 2700 nM
Estimate against measurement, compound 4: 1.3-fold (0.11 log units) above; the measured number falls inside the stated range.
By their numbers in this assay, from the lowest: compounds 2, 4, 1 and 3 (each within the scatter of the next).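

A fourth aryl group at this place, carrying trifluoromethyl and no methoxy, also cannot be told apart from the others in this assay (a 1.7-fold lower number from compound 3 to compound 4 (0.22 log units; within the scatter)) and (a 1.3-fold lower number from compound 1 to compound 4 (0.12 log units; within the scatter)), and the exchange of trifluoromethyl for tert-butyl on the aromatic carbon leaves almost no gap (a 1.1-fold higher number from compound 2 to compound 4 (0.03 log units; within the scatter)). The 3-methoxyphenyl, 3,4-dimethoxyphenyl, 4-(tert-butyl)phenyl and 4-(trifluoromethyl)phenyl groups thus all sit on the saturated chain carbon bound to an amine nitrogen with no step among them beyond the scatter, so no preference among these four groups can be read at this position. No measurement is at hand that bears on why these values lie so close together.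

Still open, from the compounds shown here alone, is whether any aryl group at this place gives a step beyond the scatter, for instance one carrying a carboxylic acid or an amine. Going by these compounds, the shared core stays fixed in all four compounds, so the effect of a longer chain, or of an amide in place of the amine nitrogen, also remains unknown.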